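Thiazolyl for Pyridyl on the Amide Nitrogen of a TRPM8 Agonist

This account rests on a few compounds, and the source may have more. Where it says the series, first, only, none or still open, it means among the compounds named here.

Three compounds have numbers in an assay on HEK293 cells for agonist activity at transient receptor potential cation channel subfamily M member 8 (Homo sapiens), read by fluorescence and calcium flux, with a stated time of 15 min; a lower number here means that less compound is needed, a higher number that more compound is needed for the effect. Compound 1 `Cc1ccc(OCC(=O)N(Cc2cccs2)c2cccnc2)cc1` gives 198 nM and stands second highest of the three. Compound 2 `CCN(Cc1cncs1)C(=O)COc1ccc(C)cc1` gives 1100 nM, the nearest value to compound 1, and the gap between them lies beyond the scatter. Compound 3 `CCN(Cc1cccs1)C(=O)COc1cc(C)ccc1O` gives 24 nM, the furthest from compound 1, again beyond the scatter. Within the data shown here, the measured compounds share no single-point change with one another, so no measured step speaks directly to the change at hand.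

Compound 4 `Cc1ccc(OCC(=O)N(Cc2cccs2)c2nccs2)cc1` differs from compound 1 by 1,3-thiazol-2-yl in place of pyridin-3-yl on an amide-type nitrogen. The core, the aryloxyacetamide chain and the thiophen-2-ylmethyl group stay as they are. Among the measured compounds shown here, since no measured pair shows this exchange, the expectation rests on the general sense that swapping one small heteroaryl for another on this nitrogen tends not to move the number far. The step from compound 1 to compound 4 is expected to be small and of uncertain direction, a 1.3-fold higher number from compound 1 to compound 4 (0.10 log units; within the scatter), within or just at the edge of the scatter. Compound 4 is therefore estimated at 250 nM, with a range from 80 nM to 800 nM.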

Compound 4, half-maximal effective concentration: 2240 nM
Beside the measured number, compound 4's estimate is 9.0-fold (0.95 log units) below it; measured number outside the range, above it.
By their numbers in this assay, from the lowest: compound 3; then compound 1; then compound 2; then compound 4.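

In this assay, the exchange on the amide-type nitrogen gives an 11-fold higher number from compound 1 to compound 4 (1.05 log units; beyond the scatter), a large step with the core, the aryloxyacetamide chain and the thiophen-2-ylmethyl group all unchanged. Among these compounds, this is the first direct reading at this position, and it shows that 1,3-thiazol-2-yl cannot stand in for pyridin-3-yl here without a clear change in the number, even though both are single aromatic rings. Nothing in the available data indicates which difference between the two rings lies behind the step.

A single step cannot show whether pyridin-3-yl is especially favourable or 1,3-thiazol-2-yl especially unfavourable at this nitrogen, and the compounds shown do not place a plain phenyl ring or a 1,3-oxazol-2-yl group relative to either. On these data alone, whether the exchange would have a similar size with another aryloxy group also remains open.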